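Removing the aminoacyl group from a ring nitrogen

The compounds below may be only part of what the source reports. "The series", "measured", "known", "first", "only" and "open" are said of these compounds alone.

This small set shares one core, an aminoquinoline-like head joined through a chain to a five-membered ring with two nitrogens, and differs in what sits on that ring. Compound 1 `COc1cc(NC(C)CCCN2C(=O)[C@@H](C)N(C(=O)CN)C2(C)C)c2ncccc2c1` carries an (aminomethyl)carbonyl group on the ring nitrogen. In a physicochemical assay for lipophilicity, measured as octanol-water partition (on this read-out higher numbers stand for higher lipophilicity and lower numbers for lower lipophilicity), compound 1 gives 2.54, the lowest of the three numbers. Compound 2 `COc1cc(NC(C)CCCN2C(=O)CN(C(=O)[C@H](N)CCSC)C2(C)C)c2ncccc2c1` gives 2.94 in this assay, and compound 3 `COc1cc(NC(C)CCCN2C(=O)CN(C(=O)[C@H](N)CC(C)C)C2(C)C)c2ncccc2c1` gives 3.36. Going by the values given here, the only step measured within a single place is a number 0.42 log units higher from compound 2 to compound 3 (beyond the scatter), and it concerns the side chain on the aminoacyl group, not the ring nitrogen itself.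

Compound 4 `COc1cc(NC(C)CCCN2C(=O)[C@@H](C)NC2(C)C)c2ncccc2c1` has not been measured. The change from compound 1 is hydrogen in place of (aminomethyl)carbonyl on an amine nitrogen in a ring. Among the compounds with values here, no measured step covers this kind of removal, so the expectation rests on what leaves: an amide carbonyl together with a primary amine, both counted as hydrogen-bond partners, while the ring nitrogen becomes a free amine. The number is therefore expected to rise modestly rather than fall, with wide uncertainty, a step of a number 0.46 log units higher from compound 1 to compound 4 (beyond the scatter). Compound 4 is estimated at 3, between 2.4 and 3.6.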

Compound 4, partition coefficient: 3.25
The estimate for compound 4 lay 0.25 log units below the measured number; measured number inside the range.
By their numbers in this assay, from the lowest: compound 1; then compound 2; then compounds 4 and 3 (each within the scatter of the next).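

Replacing (aminomethyl)carbonyl with hydrogen on the amine nitrogen in the ring gives a number 0.71 log units higher from compound 1 to compound 4 (beyond the scatter) in this assay for this one pair. Going by these compounds alone, this is the first measured change at the ring nitrogen itself, whereas the earlier step, a number 0.42 log units higher from compound 2 to compound 3 (beyond the scatter), concerned only the side chain of the aminoacyl group. No measurement here explains this change at the ring nitrogen.

As far as these compounds go, it remains open whether the step follows the loss of the whole group or of only one part of it, and an acetyl group on the same nitrogen, which keeps the carbonyl but has no amine, could separate the two. A simple methyl group at this nitrogen, or a longer chain between the carbonyl and the amine, would show how other replacements compare with compound 1 and compound 4.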